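A few compounds are considered here, and "the series" means these few. Any claim that something is new, unique, unknown or untested is made for them only; others in the source may bear on it.

Going by the values given here, compound 1 `O=C1CC(c2nc(-c3ccc(F)cc3)no2)CN1c1ccc(Cl)cc1` gives 1700 nM in an in vitro functional assay on HEK293-A cells for positive allosteric modulation of metabotropic glutamate receptor 5 (Homo sapiens), read by FLIPR and calcium flux (a lower number here means that less compound is needed, a higher number that more compound is needed for the effect), the second highest of the three numbers so far: compound 3 `COc1cccc(-c2noc(C3CC(=O)N(c4ccc(Cl)cc4)C3)n2)c1` sits nearest with 4800 nM, and compound 2 `O=C1CC(c2nc(-c3cccc(Cl)c3)no2)CN1c1ccc(Cl)cc1` furthest with 140 nM. Compound 4 `O=C1CC(c2nc(-c3ccc(F)cc3)no2)CN1c1ccc(Cl)c(Cl)c1` differs from compound 1 by chloro in place of hydrogen on an aromatic carbon, on the six-membered aromatic ring of carbon only that already carries a chloro group, ortho to that chloro group. Among the compounds with values here, no measured step touches this ring; the three known steps, a 12-fold lower number from compound 1 to compound 2 (1.08 log units; beyond the scatter), a 2.8-fold higher number from compound 1 to compound 3 (0.45 log units; beyond the scatter) and a 34-fold higher number from compound 2 to compound 3 (1.54 log units; beyond the scatter), all change the other aromatic ring attached to the shared core. For the step from compound 1 to compound 4 a modest change at most is therefore expected, a 1.5-fold lower number from compound 1 to compound 4 (0.19 log units; within the scatter). Compound 4 is estimated at 1100 nM, with a range from 300 nM to 4500 nM.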

Compound 4, half-maximal effective concentration: 2300 nM
Compound 4: the middle estimate sits 2.1-fold (0.32 log units) below what was measured; the range from low to high includes it.
By their numbers in this assay, from the lowest: compound 2; then compounds 1 and 4 (each within the scatter of the next); then compound 3.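

Adding the chloro, which turns 4-chlorophenyl into 3,4-dichlorophenyl, gives the first measured step on this ring: a 1.4-fold higher number from compound 1 to compound 4 (0.13 log units; within the scatter) and so no change that can be told from the usual scatter. The steps on the other aromatic ring, such as a 12-fold lower number from compound 1 to compound 2 (1.08 log units; beyond the scatter) and a 2.8-fold higher number from compound 1 to compound 3 (0.45 log units; beyond the scatter), all lie beyond the scatter. No evidence is available to explain this result.

From the compounds shown here alone, whether a nitrile or an amine on this same carbon would behave like the chloro remains open. So does whether the added chloro would leave the number as little changed on the structure of compound 2.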